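Chain-linked aryl ketone ethers: carboxyphenyl replacing methyl ester

The source may hold more compounds than are shown below. What is called first, only, known or untested is meant among the compounds shown, and "the series" means these compounds.

Compound 1 `COC(=O)c1ccc(OCCCCOc2ccc(C(=O)CC3CCCC3)c(O)c2C)cc1` has no result in an assay on HEK293 cells for positive allosteric modulation of metabotropic glutamate receptor 2 (Rattus norvegicus), read by thallium flux, with a stated time of 2.5 min; on this read-out higher numbers stand for an effect only at larger amounts of compound and lower numbers for an effect already at smaller amounts; its entry stands as "not determined" (no result reported), so it cannot be placed anywhere on the scale of this series. Compound 2 `COC(=O)c1ccc(OCCCCOc2ccc(C(=O)CC3CCCC3)c(C)c2C)cc1` likewise carries "not determined" (no result reported) in this assay. Within the data shown here, the only measured member is compound 3 `CCC(=O)c1ccc(OCCCCOc2cc(C(=O)O)ccc2OC)c(C)c1O`, which in this assay gives 162 nM. Among the measured compounds shown here, with a single number in hand and nothing for compound 1, no step between measured compounds can be counted, and compound 1 stands only as a structure that shares the chain-linked diaryl ether arrangement and the ketone-bearing core with compound 3.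

Compound 4 `Cc1c(OCCCCOc2cccc(C(=O)O)c2)ccc(C(=O)CC2CCCC2)c1O` is the next member to be run. From compound 1 it differs in one place: 3-carboxyphenyl in place of 4-(methoxycarbonyl)phenyl on an oxygen on a saturated carbon. Compound 1 offers no number to step from, and the direction or size of this change is not fixed by the pair; it can only be said that the free carboxylic acid of compound 4 has a counterpart in compound 3, which gives 162 nM in this assay. Resting on that one anchor, compound 4 is expected to land near 300 nM, with an estimated range from 60 nM to 1500 nM.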

Compound 4, half-maximal effective concentration: 451 nM
For compound 4 the middle estimate is 1.5-fold (0.18 log units) below the measured one, and the stated range covers the measured number.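

In this assay compound 4 gives 451 nM while compound 1 stands at "not determined" (no result reported) so no step can be read between them. The compounds shown leave open whether 3-carboxyphenyl in place of 4-(methoxycarbonyl)phenyl moves the read-out at all, or in which direction. No supporting evidence bears on this result.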